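A few compounds are considered here, and "the series" means these few. Any claim that something is new, unique, unknown or untested is made for them only; others in the source may bear on it.

The measured compounds:
Compound 1 `COC(=O)c1cc(OCC(=O)[C@H](CC(=O)O)NC(=O)[C@@H](NC(=O)COc2cccc3ccccc23)C(C)C)no1` gives in a functional assay on Jurkat cells (Homo sapiens) for inhibition (a lower number here means a stronger inhibitor, a higher number a weaker inhibitor), a value of 71000 nM.
Compound 2 `CC(C)[C@H](NC(=O)COc1cccc2ccccc12)C(=O)N[C@@H](CC(=O)O)C(=O)CSc1nc[nH]n1` gives in this assay only a limit, > 200000 nM.
Compound 3 `CC(C)[C@H](NC(=O)COc1cccc2ccccc12)C(=O)N[C@@H](CC(=O)O)C(=O)COc1ccncn1` gives in this assay only a limit, > 200000 nM.

Compound 3 therefore stands at the top end of what is known here: no number, only a limit, and it shares that position with compound 2 (the limit of > 200000 nM in this assay, at which 2 of the 3 values shown sit). Among the measured compounds shown here, compound 1 is the sole compound of the three with a measured number.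

Compound 4 `CC(C)[C@H](NC(=O)COc1cccc2ccccc12)C(=O)N[C@@H](CC(=O)O)C(=O)COc1cc2ccccc2cn1` has not yet been measured. It differs from compound 3 in one place: isoquinolin-3-yl in place of pyrimidin-4-yl on an oxygen on a saturated carbon.

For the measured compounds named here, two measured steps bear on exchanges of the aryl group at this position. The step of an at least 2.8-fold higher number from compound 1 to compound 3 (0.44 log units; beyond the scatter) and the step of an at least 2.8-fold higher number from compound 1 to compound 2 (0.44 log units; beyond the scatter) both show that changing the aryl on the oxygen or the sulfur of the chain can weaken inhibition beyond the scatter. The step that the two limits leave unreadable from compound 2 to compound 3 cannot be read, since both ends are limits.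

With compound 3 already at the limit, and no measured case of a move back toward a number from that position, the step of an at least 1.3-fold lower number from compound 3 to compound 4 (0.12 log units; that floor lies within the scatter) is expected to be small and as likely to remain unreadable as not. Compound 4 is estimated at 150000 nM, within the range 40000 nM to 400000 nM.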

Compound 4, half-maximal inhibitory concentration: > 200000 nM
Compound 4: a limit, no number (the forecaster's own chance of this, stated with the estimate: 55%); middle value at least 1.3-fold (0.12 log units) away from the limit.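

In this assay compound 4 gives only a limit, > 200000 nM. Replacing pyrimidin-4-yl with the larger isoquinolin-3-yl, which carries a second six-membered aromatic ring, therefore yields no number, and the steps among compound 2, compound 3 and compound 4 cannot be read. The one readable step, an at least 2.8-fold higher number from compound 1 to compound 4 (0.44 log units; beyond the scatter), is the third replacement of the 5-(methoxycarbonyl)-1,2-oxazol-3-yl group to end at a limit, so a single-ring and a two-ring aromatic group on this oxygen now both give the same outcome, and the position reads: the limit of > 200000 nM in this assay, at which 3 of the 4 values shown sit.

The compounds shown leave open whether the number seen with compound 1 depends on the methoxycarbonyl group or on the 1,2-oxazol-3-yl ring that carries it, a question that a carboxylic acid or a primary amide in place of the methoxycarbonyl group on that same ring would address. They also leave open how compound 2, compound 3 and compound 4 rank against one another, since each is known only as a limit.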